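Acid to Ester on a Shared Core: Expected Dose

This account rests on a few compounds, and the source may have more. Where it says the series, first, only, none or still open, it means among the compounds named here.

Measured compounds:
compound 1 `CCOc1ccc(N(C)C)cc1-c1ncc(C(=O)O)c(=O)[nH]1`, 0.3 mg/kg in a functional assay on the whole organism (strain Sprague-Dawley) for inhibition, with Rattus norvegicus as the target, with a stated time of 10 min; a higher number here means that more compound is needed for the effect, a lower number that less compound is needed
compound 2 `CCOC(=O)C(=O)Nc1ccc(OCC)c(-c2ncc(C(=O)O)c(=O)[nH]2)c1`, 25 mg/kg in this assay
compound 3 `CCOC(=O)c1cnc(-c2cc(N(C)C)ccc2OCC)[nH]c1=O`, "not determined" (no result reported) in this assay

Compound 4 `CCOC(=O)C(=O)Nc1ccc(OCC)c(-c2ncc(C(=O)OCC)c(=O)[nH]2)c1` has not yet been measured. Its core differs from that of compound 1 by ethyl in place of hydrogen on an oxygen next to a carbonyl group; this is the core of compound 3, for which no number exists in this assay. The change from compound 3 to compound 4 is ((ethoxycarbonyl)carbonyl)amino in place of dimethylamino on an aromatic carbon. The same change, (((ethoxycarbonyl)carbonyl)amino in place of dimethylamino on an aromatic carbon), was made once before with a measured outcome: an 83-fold higher number from compound 1 to compound 2 (1.92 log units; beyond the scatter). The place lines of the two changes read the same word for word, so this is the same change on two cores.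

Because compound 3 has no result in this assay, the size of the step from compound 3 to compound 4 cannot be set against the earlier one; the expectation rests instead on compound 2, whose value 25 mg/kg shares with compound 4 the whole structure except the core difference (ethyl in place of hydrogen on an oxygen next to a carbonyl group). For compound 4 the estimated value in this assay is 25 mg/kg, with a range from 5 mg/kg to 120 mg/kg.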

Compound 4, dose for 50% inhibition: 5 mg/kg
Beside the measured number, compound 4's estimate is 5.0-fold (0.70 log units) above it, within the range that was stated.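

In this assay, putting ethyl in place of hydrogen on an oxygen next to a carbonyl group gives a 5.0-fold lower number from compound 2 to compound 4 (0.70 log units; beyond the scatter), a modest step beyond the usual scatter, and it shows only that, with ((ethoxycarbonyl)carbonyl)amino present, the ethyl ester needs less compound than the carboxylic acid. On the core of compound 1, the swap from dimethylamino to ((ethoxycarbonyl)carbonyl)amino gives an 83-fold higher number from compound 1 to compound 2 (1.92 log units; beyond the scatter), but the steps that start from compound 3 cannot be read: compound 3 has no reported result, so neither the size of that swap on the ethyl ester core nor the effect of the ethyl change with dimethylamino present is known. Nothing given here explains the size of either step.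

One pair of compounds cannot set a rule for the series. Going by these compounds, it remains open whether a methyl ester, a longer chain on the ester oxygen, or a primary amide in place of the ester would shift the dose in the same direction.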